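The compounds below may be only part of what the source reports. "The series", "measured", "known", "first", "only" and "open" are said of these compounds alone.

Measured in a functional assay on MCF7 cells (Homo sapiens) for antiproliferative activity, read by sulforhodamine B assay, with a stated time of 72 h; a lower number here means a stronger inhibitor, a higher number a weaker inhibitor:
- Compound 1 `COc1cc(/C=C2\CN(C(=O)OCc3ccccc3)C=CC2=O)cc(OC)c1OC`: > 25000 nM, a limit
- Compound 2 `COc1cc(/C=C2\CNC=CC2=O)cc(OC)c1OC`: > 25000 nM, a limit
- Compound 3 `COc1cc(/C=C2\CN(S(=O)(=O)c3ccccc3)C=CC2=O)cc(OC)c1OC`: > 25000 nM, a limit

Compound 3 has no exact number on this scale. Its value of > 25000 nM is a limit of the assay, and it shares this position with the other two compounds: the limit of > 25000 nM in this assay, at which 3 of the 3 values shown sit.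

Compound 4 `COc1cc(/C=C2\CN(S(=O)(=O)c3ccc(C)cc3)C=CC2=O)cc(OC)c1OC` has methyl in place of hydrogen on an aromatic carbon, turning phenylsulfonyl into (4-methylphenyl)sulfonyl (methyl in place of hydrogen on an aromatic carbon).

Among the compounds with values here, three measured steps bear on this small change: a step that the two limits leave unreadable from compound 1 to compound 2, a step that the two limits leave unreadable from compound 1 to compound 3 and a step that the two limits leave unreadable from compound 2 to compound 3. None has a readable size, even though these steps swap whole groups on the ring nitrogen. They therefore offer no sign that a single added methyl should bring activity into measurable range in this assay.

The expected result is a step that the limit leaves unreadable from compound 3 to compound 4, with no change beyond the scatter anticipated. A further limit is the most likely report. For compound 4 the estimated value is 30000 nM, with an expected range of 12000 nM to 60000 nM.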

Compound 4, half-maximal inhibitory concentration: 19200 nM
Beside the measured number, compound 4's estimate is 1.6-fold (0.19 log units) above it; the measured number falls inside the stated range.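

Compound 4 is the only compound here with an exact number in this assay, which shows that a methyl on this aromatic carbon of the phenylsulfonyl group is compatible with a value on the scale, while the others remain limits: the limit of > 25000 nM in this assay, at which 3 of the 4 values shown sit.

The size of the change stays uncertain, as the methyl gives an at least 1.3-fold lower number from compound 3 to compound 4 (0.11 log units; that floor lies within the scatter). Replacing the groups on the ring nitrogen gives an at least 1.3-fold lower number from compound 2 to compound 4 (0.11 log units; that floor lies within the scatter) and an at least 1.3-fold lower number from compound 1 to compound 4 (0.11 log units; that floor lies within the scatter), which are also only floors, and the steps among compound 1, compound 2 and compound 3 cannot be read.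

From the compounds shown here alone, whether an ethyl group, a longer chain or a chlorine atom at the same carbon would give a step beyond the scatter remains open. So does the effect of an amine or a carboxylic acid there.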